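The compounds below may be only part of what the source reports. "The series", "measured", "known", "first", "only" and "open" are said of these compounds alone.

Measured compounds:
compound 1 `CS(=O)(=O)NC(=O)c1ccc(C2CC2c2ccc(OCc3c(-c4c(Cl)cccc4Cl)noc3C3CC3)cc2Cl)cc1` — 100%
compound 2 `Cn1nc(C(=O)O)c2ccc(C3CC3c3ccc(OCc4c(-c5c(Cl)cccc5Cl)noc4C4CC4)cc3Cl)cc21` — 104%

In an assay on isolated protein for agonist activity at Bile acid receptor (Homo sapiens), read by FRET (a higher number here means a larger maximal response, a lower number a smaller maximal response), compound 1 gives 100%. Compound 2 gives 104% in this assay; the two numbers lie within the usual scatter of one another and are read as alike. Compound 3 `O=C(NCCS(=O)(=O)O)c1ccc(C2CC2c2ccc(OCc3c(-c4c(Cl)cccc4Cl)noc3C3CC3)cc2Cl)cc1` has not been measured. It differs from compound 1 in one place: 2-sulfoethyl in place of methylsulfonyl on an amide-type nitrogen. For the measured compounds named here, no measured pair shows a change of this kind, so nothing directly supports a step. Because compound 1 gives 100% and compound 2 gives 104%, a step no larger than the scatter is expected, a number 4 percentage points lower from compound 1 to compound 3 (within the scatter). Compound 3 is estimated at 96%, within 72% to 112%.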

Compound 3, largest response reached (reported as efficacy), in percent of the reference or control that the assay uses: 98%
Beside the measured number, compound 3's estimate is 2 percentage points below it; the range from low to high includes it.
By their numbers in this assay, from the lowest: compounds 3, 1 and 2 (each within the scatter of the next).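

On the amide-type nitrogen, 2-sulfoethyl in place of methylsulfonyl gives, in this assay, a number 2 percentage points lower from compound 1 to compound 3 (within the scatter). For the compounds shown here, this is the first change read at this position, and it shows that the largest response reached stays alike when one of these two groups replaces the other. No measured property accounts for this result.

From the compounds shown here alone, whether a carboxylic acid or an amine at the end of a 2-carbon chain on this nitrogen would also read alike remains open. So does the outcome with a longer chain ending in the sulfonic acid.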